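This account rests on a few compounds, and the source may have more. Where it says the series, first, only, none or still open, it means among the compounds named here.

Measured so far:
Compound 1, `O=C(CBr)Nc1ccc(C(=O)/C=C/c2ccco2)cc1`: 37%
Compound 2, `CC(O[N+](=O)[O-])C(=O)Nc1ccc(C(=O)/C=C/c2ccc(Cl)cc2)cc1`: 55%

Both compounds were tested in a functional assay on the whole organism (strain albino) for inhibition, with Rattus norvegicus as the target, read by paw edema, with stated times of 30 min and 2 h, at a dose of 100 mg/kg by the oral route; a lower number here means less inhibition, a higher number more inhibition at the dose given (going by the name of the read-out). Compound 1 gives 37% there, and compound 2 gives 55%. Of the two numbers, compound 2 stands highest; compound 1 lies a stretch below it that goes beyond the usual scatter of repeated measurements of this kind. Within the data shown here, no pair of measured compounds differs in only one place, so no measured step can guide the next move directly.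

Compound 3, `CC(O[N+](=O)[O-])C(=O)Nc1ccc(C(=O)/C=C/c2ccco2)cc1`, has not yet been measured. It differs from compound 2 in one place: furan-2-yl in place of 4-chlorophenyl on a double-bonded chain carbon bound to a double-bonded chain carbon. A direction can still be guessed, because compound 1 with the same furan-2-yl gives only 37% while carrying a different amide side chain. The expected change is a number 10 percentage points lower from compound 2 to compound 3 (within the scatter), a modest drop in this assay, though the size of that drop is uncertain. Compound 3 is therefore estimated at 45%, within a range from 30% to 60%.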

Compound 3, a percentage reported as inhibition, in the whole organism at one dose (the size of the read-out at that dose, not a potency): 48%
Compound 3: middle estimate off by 3 percentage points, on the low side; low and high end bracket the measured number.
By their numbers in this assay, from the lowest: compound 1; then compounds 3 and 2 (each within the scatter of the next).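

In this assay, furan-2-yl in place of 4-chlorophenyl on a double-bonded chain carbon bound to a double-bonded chain carbon gives a number 7 percentage points lower from compound 2 to compound 3 (within the scatter) and so leaves the two compounds unranked: at this place, a five-membered aromatic ring with one oxygen reads the same as a larger six-membered carbon ring carrying chlorine, as far as this read-out can tell. Among these compounds, the other new step, 1-(nitrooxy)ethyl in place of bromomethyl on a carbonyl carbon, gives a number 11 percentage points higher from compound 1 to compound 3 (beyond the scatter) with furan-2-yl held constant, which shows for the first time that the group on the carbonyl carbon alone can shift the number beyond the scatter. No measurement at hand explains either step.

Going by these compounds, whether the same holds for other rings at the first place, such as a plain phenyl or a thiophene-2-yl ring, remains open. On these data alone, it is also open whether the nitrooxy part of the side chain matters, which a simple ethyl or an aminomethyl group on the carbonyl carbon could help to settle.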